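From 4-chlorophenyl to 4-methoxyphenyl in a flat series

The source may report more compounds than this note shows. Statements on the series, on what has been measured and on what is new or still open speak of the compounds shown alone.

In a functional assay on MCF7 cells (Homo sapiens) for antiproliferative activity, read by MTT assay, with a stated time of 48 h (a lower number here means a stronger inhibitor, a higher number a weaker inhibitor), compound 1 `O=C(/C=C/c1ccc(C(F)(F)F)cc1)Nc1nnc(-c2ccc(Br)cc2)s1` gives 1.58 ug/mL, compound 2 `O=C(/C=C/c1ccc(C(F)(F)F)cc1)Nc1nnc(-c2ccccc2)s1` gives 1.52 ug/mL and compound 3 `O=C(/C=C/c1ccc(C(F)(F)F)cc1)Nc1nnc(-c2ccc(Cl)cc2)s1` gives 1.65 ug/mL. Compound 3 therefore stands level with the other two, within the scatter. Compound 4 `COc1ccc(-c2nnc(NC(=O)/C=C/c3ccc(C(F)(F)F)cc3)s2)cc1` carries a single change, methoxy in place of chloro on an aromatic carbon, para to a large group. The measured steps at this place are a 1.1-fold higher number from compound 2 to compound 3 (0.04 log units; within the scatter), a 1.0-fold higher number from compound 1 to compound 3 (0.02 log units; within the scatter) and a 1.0-fold lower number from compound 1 to compound 2 (0.02 log units; within the scatter), each within the scatter. None of them introduces methoxy, so direct precedent is lacking. The expected step is a 1.0-fold lower number from compound 3 to compound 4 (0.01 log units; within the scatter), with no shift beyond the scatter anticipated in either direction. The estimate for compound 4 is 1.6 ug/mL, with an expected range of 0.8 ug/mL to 3.2 ug/mL.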

Compound 4, half-maximal inhibitory concentration: 0.79 ug/mL
For compound 4 the middle estimate is 2.0-fold (0.31 log units) above the measured one; the whole stated range lies above it.
By their numbers in this assay, from the lowest: compounds 4, 2, 1 and 3 (each within the scatter of the next, the first and the last beyond it).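

In this assay, among the compounds shown here, this position no longer looks wholly flat: hydrogen, bromo and chloro stand level, whereas methoxy gives a 2.1-fold lower number from compound 3 to compound 4 (0.32 log units; beyond the scatter) as the only step here beyond the scatter. The other two steps, a 1.9-fold lower number from compound 2 to compound 4 (0.28 log units; within the scatter) and a 2.0-fold lower number from compound 1 to compound 4 (0.30 log units; within the scatter), remain within it, so the effect is modest and rests on the comparison with chloro alone. No measured evidence accounts for this step.

Open, on these data alone, is whether a hydroxyl, an amine or a longer alkoxy chain such as ethoxy at this place would extend the step seen with methoxy. Also open, as far as these compounds go, is whether the same step would hold on a core other than that of compound 4.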